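This account rests on a few compounds, and the source may have more. Where it says the series, first, only, none or still open, it means among the compounds named here.

Within the data shown here, compound 1 `O=C(Nc1ccc(-n2ccc3c(NC(=O)c4ccccc4)ncnc32)cc1)c1ccc(Cl)c(Cl)c1` is, among the three compounds measured so far, the one with the lowest number in a functional assay on A375P cells (Homo sapiens) for antiproliferative activity, read by MTT assay, with a stated time of 24 h (a higher number here means a weaker inhibitor, a lower number a stronger inhibitor), where compound 1 gives 2000 nM. Compound 2 `Nc1ncnc2c1ccn2-c1ccc(NC(=O)Nc2cc(C(F)(F)F)cc(C(F)(F)F)c2)cc1` gives 3000 nM in this assay, a value within the scatter of compound 1, so no order between the two can be claimed. Compound 3 `O=C(Nc1ccc(-n2ccc3c(NC(=O)c4ccccc4)ncnc32)cc1)Nc1cc(C(F)(F)F)cc(C(F)(F)F)c1` gives 9800 nM in this assay, the highest of the three.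

Compound 4 `O=C(Nc1ccc(-n2ccc3c(NC(=O)c4ccccc4)ncnc32)cc1)Nc1cccc(Cl)c1Cl` differs from compound 1 in one place: (2,3-dichlorophenyl)amino in place of 3,4-dichlorophenyl on a carbonyl carbon. Among the measured compounds shown here, no measured pair shows exactly this change. For the measured compounds named here, the only measured step, a 3.3-fold higher number from compound 2 to compound 3 (0.51 log units; beyond the scatter), concerns a different position, the benzoyl on the core that compound 1 and compound 4 share, so it bears on the question only indirectly. What the numbers do show is that compound 3, which carries a carbamoyl-type linker like compound 4, sits well above compound 1 in this assay. On that slim basis a modest weakening is expected, with a 2.0-fold higher number from compound 1 to compound 4 (0.30 log units; within the scatter); compound 4 is estimated at 4000 nM, within a range from 1500 nM to 12000 nM.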

Compound 4, half-maximal inhibitory concentration: 4100 nM
For compound 4 the middle estimate is 1.0-fold (0.01 log units) below the measured one, and the stated range covers the measured number.
By their numbers in this assay, from the lowest: compounds 1, 2 and 4 (each within the scatter of the next, the first and the last beyond it); then compound 3.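

In this assay, among these compounds, putting (2,3-dichlorophenyl)amino in place of 3,4-dichlorophenyl on a carbonyl carbon gives a 2.1-fold higher number from compound 1 to compound 4 (0.31 log units; beyond the scatter), the first reading at this position, since the earlier step concerned a benzoyl elsewhere on the molecule. The step is small but beyond the scatter, and it changes two things at once: the entering group brings a nitrogen and a hydrogen-bond donor, and its chlorines carry different ring numbers. Nothing shown here explains the difference.

From the compounds shown here alone, it remains open whether (3,4-dichlorophenyl)amino on the same carbonyl carbon would read nearer compound 1 or compound 4, a comparison that would separate the added nitrogen from the change in chlorine numbering. Going by these compounds, how an unsubstituted phenyl or a morpholine would fare at this place also remains open.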